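This account rests on a few compounds, and the source may have more. Where it says the series, first, only, none or still open, it means among the compounds named here.

Working notes on the series built on the shared core of compound 1 `COc1ccc(-c2cc(=O)c3c(OC)cc(OC)cc3n2C)cc1`. In a functional assay on KOPN-8 cells (Homo sapiens) for antiproliferative activity, with a stated time of 72 h (on this read-out lower numbers stand for an effect already at smaller amounts and higher numbers for an effect only at larger amounts of compound), compound 1 gives 30000 nM. Compound 2 `C=CCNC(=O)n1c(-c2ccc(OC)cc2)cc(=O)c2c(OC)cc(OC)cc21` gives 12000 nM in this assay, and the step of a 2.5-fold lower number from compound 1 to compound 2 (0.40 log units; beyond the scatter) is the only one in this set toward a lower number. Compound 3 `COc1ccc(-c2cc(=O)c3c(OC)cc(OC)cc3n2S(=O)(=O)c2ccc(F)cc2)cc1` sits at the limit described by the limit of > 65500 nM in this assay, at which 1 of the 3 values shown sits; in this assay compound 3 gives > 65500 nM, which is a limit of the assay and not a number. On the numbers shown compound 3 therefore stands at the weak end of the series, with an at least 2.1-fold higher number from compound 1 to compound 3 (0.33 log units; beyond the scatter) and an at least 5.4-fold higher number from compound 2 to compound 3 (0.73 log units; beyond the scatter) both pointing to higher numbers.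

Compound 4 `COc1ccc(-c2cc(=O)c3c(OC)cc(OC)cc3n2S(=O)(=O)c2ccc(C)cc2)cc1` carries the change (methyl in place of fluoro on an aromatic carbon). Within the data shown here, no measured pair swaps fluoro for methyl on the sulfonyl aryl, so no step addresses this change directly; the steps that bear on it are an at least 2.1-fold higher number from compound 1 to compound 3 (0.33 log units; beyond the scatter) and an at least 5.4-fold higher number from compound 2 to compound 3 (0.73 log units; beyond the scatter), which place the (4-fluorophenyl)sulfonyl compound beyond the measurable range. Because the starting point is the limit (the limit of > 65500 nM in this assay, at which 1 of the 3 values shown sits), the expectation is that the swap produces no step beyond the scatter, written as a step that the limit leaves unreadable from compound 3 to compound 4. Compound 4 is estimated at 80000 nM, with a range from 30000 nM to 200000 nM, and is expected most likely to be reported again only as a limit.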

Compound 4, half-maximal effective concentration: > 44800 nM
Compound 4 was reported as a limit (the forecaster's own chance of this, stated with the estimate: 70%); the middle value is on the limit's open side.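

Methyl in place of fluoro on an aromatic carbon, para to a large group, still gives no number for compound 4, whose result is a limit of the assay: the limit of > 44800 nM in this assay, at which 1 of the 4 values shown sits.

Compound 3 also has only a limit of the assay, so the step between the two cannot be read and neither fluoro nor methyl can be ranked ahead of the other: the limit of > 65500 nM in this assay, at which 1 of the 4 values shown sits.

The new information lies in the comparisons on the aromatic nitrogen: there is an at least 3.7-fold higher number from compound 2 to compound 4 (0.57 log units; beyond the scatter), so the gap from the allylcarbamoyl compound recurs with a second sulfonyl group, whereas an at least 1.4-fold higher number from compound 1 to compound 4 (0.17 log units; that floor lies within the scatter) has a floor that does not separate (4-methylphenyl)sulfonyl from methyl, unlike the printed step for (4-fluorophenyl)sulfonyl.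

The compounds shown leave open whether any arylsulfonyl compound can give a true number, for example with an amine or a carboxylic acid in place of methyl or fluoro on that aromatic carbon. They also leave open whether a longer chain on the carbamoyl nitrogen, in place of allyl, would extend the lower number seen for compound 2.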